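The source may hold more compounds than are shown below. What is called first, only, known or untested is meant among the compounds shown, and "the series" means these compounds.

Measured compounds in a functional assay on RMS13 cells for antagonist activity at Urotensin-2 receptor (Homo sapiens), read by FLIPR and calcium flux, with a stated time of 1 h; on this read-out lower numbers stand for stronger inhibition and higher numbers for weaker inhibition:

compound 1 `CCN1CCN(c2cccc3c2C(=O)N([C@H](CCCNS(=O)(=O)c2cn(C)c(C)n2)c2ccc(OC)c(OC)c2)C3=O)CC1`: 810 nM
compound 2 `COc1ccc([C@@H](CCCN(C)S(=O)(=O)c2cccs2)N2Cc3c(cccc3N3CCN(C4CC4)CC3)C2=O)cc1OC`: 1200 nM
compound 3 `CCN1CCN(c2cccc3c2CN([C@H](CCCNC(=O)c2cccs2)c2ccc(OC)c(OC)c2)C3=O)CC1`: 140 nM

The three compounds share a core and differ in the side chain and in the group on the piperazine ring nitrogen. Among them, compound 2 has the highest number in this assay, and compound 1 sits within the scatter of it, so the two cannot be told apart. Compound 3 stands well apart from compound 2, with a number beyond the scatter and clearly stronger inhibition.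

The next compound, compound 4 `COc1ccc([C@@H](CCCN(C)S(=O)(=O)c2cccs2)N2Cc3c(cccc3N3CCNCC3)C2=O)cc1OC`, is not yet measured. It differs from compound 2 in one place: hydrogen in place of cyclopropyl on an amine nitrogen in a ring. For the measured compounds named here, nothing among the measured compounds tracks this exact change, since compound 1 and compound 3 carry an ethyl group there rather than a hydrogen, so the expectation rests on general judgement only. The step from compound 2 to compound 4 is expected to be small, possibly a slight weakening, and likely not beyond the scatter, as a 1.3-fold higher number from compound 2 to compound 4 (0.10 log units; within the scatter) conveys. Compound 4 is therefore estimated at 1500 nM, with a range from 500 nM to 4500 nM.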

Compound 4, half-maximal inhibitory concentration: 410 nM
Estimate against measurement, compound 4: 3.7-fold (0.56 log units) above, outside the stated range (below it).
By their numbers in this assay, from the lowest: compound 3; then compounds 4, 1 and 2 (each within the scatter of the next, the first and the last beyond it).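

Within this assay the change from 4-cyclopropylpiperazin-1-yl to piperazin-1-yl gives a 2.9-fold lower number from compound 2 to compound 4 (0.47 log units; beyond the scatter) and is the first clean reading at this position, as the earlier compounds differ from one another in more than one place. For this side chain, then, the amine nitrogen in the ring needs no carbon group to keep its activity, and the cyclopropyl group costs a modest amount of inhibition. Nothing at hand explains why the number falls with this change.

The compounds shown leave open where a methyl group, an isopropyl group or an acetyl group on this nitrogen would fall relative to hydrogen and cyclopropyl. Going by these compounds, it also remains open whether hydrogen in place of ethyl would bring a similar step on the side chain of compound 3.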